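From Compound 3 to Compound 4: Adding a Phenyl

The compounds below may be only part of what the source reports. "The series", "measured", "known", "first", "only" and "open" are said of these compounds alone.

- Compound 1 `CCCOC1=CC(=O)c2ccccc2C1=O` gives 51600 nM
- Compound 2 `Cc1ccc(S(=O)(=O)Oc2cccc3c2C(=O)C=CC3=O)cc1` gives 9470 nM
- Compound 3 `COc1ccc2c(c1)C(=O)C=CC2=O` gives 22700 nM

These values come from a functional assay on HeLa cells (Homo sapiens) for cytotoxicity (a higher number here means a weaker inhibitor, a lower number a stronger inhibitor), and they place compound 3 in the middle. Compound 3, at 22700 nM on this scale, holds the second highest of the three numbers. Compound 1 has a higher number and compound 2 a lower one, and both gaps lie beyond the usual scatter.

Compound 4 `O=C1C=CC(=O)c2cc(OCc3ccccc3)ccc21` has not yet been measured. The change from compound 3 is phenyl in place of hydrogen on a saturated chain carbon bound to an oxygen on an aromatic ring and it puts phenyl in place of hydrogen on a saturated chain carbon bound to an oxygen on an aromatic ring. For the measured compounds named here, no measured pair differs in just one place, so the guidance is thin. Going by the values given here, the largest compound so far, compound 2, gives 9470 nM as the lowest number, but that is a single case that differs from compound 3 in more than one place. In this assay a modest shift toward a stronger inhibitor is expected, perhaps no larger than the scatter. The expected step is a 1.9-fold lower number from compound 3 to compound 4 (0.28 log units; within the scatter) and it remains only an estimate. For compound 4 the estimated value is 12000 nM with an expected range of 4000 nM to 32000 nM for the coming measurement.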

Compound 4, half-maximal inhibitory concentration: 16800 nM
Beside the measured number, compound 4's estimate is 1.4-fold (0.15 log units) below it; the range from low to high includes it.
By their numbers in this assay, from the lowest: compounds 2, 4 and 3 (each within the scatter of the next, the first and the last beyond it); then compound 1.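

In this assay, for the compounds shown here, compound 3 and compound 4 form the first pair that differs in only one place, so the effect of a single change can be read directly. Putting phenyl in place of hydrogen on a saturated chain carbon bound to an oxygen on an aromatic ring gives a 1.4-fold lower number from compound 3 to compound 4 (0.13 log units; within the scatter) and stays within the scatter, so the two compounds read as equal and this position tolerates the phenyl in this assay. No supporting evidence is available to explain this result.

This single pair leaves open whether an amine or a carboxylic acid in place of the phenyl on this chain carbon would give a step beyond the scatter. It also leaves open what a longer chain carrying the phenyl would do to the number.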